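The source may report more compounds than this note shows. Statements on the series, on what has been measured and on what is new or still open speak of the compounds shown alone.

Of the compounds shown here, three that share a common core have been tested in a functional assay on HEK293 cells for negative allosteric modulation of metabotropic glutamate receptor 5 (Rattus norvegicus), read by FLIPR and calcium flux, with a stated time of 170 s; a higher number here means a weaker inhibitor, a lower number a stronger inhibitor. Compound 1, `c1ccc(-c2cc3n(n2)CCCC3)nc1`, gives 1290 nM. Compound 2, `Clc1ccc(-c2cc3n(n2)CCCC3)nc1`, differs from compound 1 by chloro in place of hydrogen on an aromatic carbon. In this assay compound 2 gives 669 nM, so the step is a 1.9-fold lower number from compound 1 to compound 2 (0.29 log units; within the scatter). Compound 3, `c1ccc(-c2cc3n(n2)CCCC3)cc1`, gives 1900 nM; how its core differs from the core of compound 1 is not broken down here. Compound 4, `Clc1ccc(-c2cc3n(n2)CCCC3)cc1`, has not yet been measured in this assay and differs from compound 3 by chloro in place of hydrogen on an aromatic carbon. Among the compounds with values here, this is the same kind of change as the one between compound 1 and compound 2, but not the same one: there the chloro enters a six-membered aromatic ring with 1 nitrogen, two atoms from the ring nitrogen, whereas here it enters a six-membered aromatic ring of carbon only. The change has been seen only once, so any expectation rests on that single earlier step, a 1.9-fold lower number from compound 1 to compound 2 (0.29 log units; within the scatter). Compound 4 is expected to show a similar small step, a 1.9-fold lower number from compound 3 to compound 4 (0.28 log units; within the scatter). Compound 4 is therefore estimated at 1000 nM, likely between 400 nM and 2500 nM.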

Compound 4, half-maximal inhibitory concentration: 4230 nM
For compound 4 the middle estimate is 4.2-fold (0.63 log units) below the measured one; measured number above the stated range.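

In this assay, placing chloro on the ring of compound 3 gives a 2.2-fold higher number from compound 3 to compound 4 (0.35 log units; beyond the scatter), so here the change makes the inhibitor modestly weaker. Set beside the earlier step, the same change does not give the same result on the two cores: the same change on two cores in this assay, a 1.9-fold lower number (0.29 log units; within the scatter) from compound 1 to compound 2 and a 2.2-fold higher number (0.35 log units; beyond the scatter) from compound 3 to compound 4, 4.3-fold (0.63 log units) apart, beyond the scatter of two such steps

A step measured on one core therefore cannot be assumed to carry over to the other, although the earlier step alone, being within the scatter, does not establish that chloro helps on the core of compound 1, and one pair on each core cannot explain why the two steps differ.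

The compounds shown carry only hydrogen or chloro on the six-membered aromatic ring, so it remains open whether a methyl group, a methoxy group or a nitrile would also fare differently on the two cores. As far as these compounds go, it also remains open whether chloro on another carbon of these rings would show the same gap.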